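This account rests on a few compounds, and the source may have more. Where it says the series, first, only, none or still open, it means among the compounds named here.

Compound 1, `Nc1ccn([C@H]2C[C@H](SS[C@H]3C[C@H](n4ccc(N)nc4=O)O[C@@H]3CO)[C@@H](CO)O2)c(=O)n1`: 216000 nM in an ADME assay on CCRF-CEM cells (Homo sapiens) for cytotoxicity; a lower number here means that less compound is tolerated, a higher number that more compound is tolerated
Compound 2, `O=c1nc(O)ccn1[C@H]1C[C@H](SS[C@H]2C[C@H](n3ccc(O)nc3=O)O[C@@H]2CO)[C@@H](CO)O1`: >= 250000 nM
Compound 3, `C=CCSS[C@H]1C[C@H](n2cc(C)c(=O)[nH]c2=O)O[C@@H]1CO`: 53000 nM

Of the compounds shown here, three have been measured in this assay. Compound 1 gives 216000 nM. For compound 2 the result is a limit rather than a number, >= 250000 nM. Compound 3 gives 53000 nM, the lower of the two numbers, with compound 1 sitting above it by a gap beyond the scatter. The one limit, (the limit of >= 250000 nM in this assay, at which 1 of the 3 values shown sits), belongs to compound 2.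

Compound 4, `Cc1cn([C@H]2C[C@H](SSCCN)[C@@H](CO)O2)c(=O)[nH]c1=O`, has not yet been measured. It differs from compound 3 in one place: aminomethyl in place of vinyl on a saturated chain carbon bound to a sulfur. Put another way, an aminomethyl stands in place of a vinyl on a saturated chain carbon bound to a sulfur, so the allyl of compound 3 becomes a 2-aminoethyl.

Going by the values given here, no measured pair shows a step of this kind, so the size of the step from compound 3 to compound 4 cannot be read from the other compounds. Since compound 3 gives 53000 nM, the expectation for compound 4 is a number near it, with at most a modest rise and nothing clearly beyond the scatter; the expected step is a 1.4-fold higher number from compound 3 to compound 4 (0.15 log units; within the scatter). The estimated value for compound 4 is 75000 nM, expected to fall between 20000 nM and 250000 nM.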

Compound 4, half-maximal cytotoxic concentration: 437000 nM
The estimate for compound 4 lay 5.8-fold (0.77 log units) below the measured number, and the stated range ends below it.
By their numbers in this assay, from the lowest: compound 3; then compound 1; then compound 4.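

In this assay, placing an aminomethyl instead of a vinyl on a saturated chain carbon bound to a sulfur gives an 8.2-fold higher number from compound 3 to compound 4 (0.92 log units; beyond the scatter), so more compound is tolerated after this change. Going by these compounds alone, this is the first direct view of this position, and it shows that the cells respond to what sits at the end of this short chain: the entering group brings a hydrogen-bond donor and a hydrogen-bond acceptor, while the leaving group brings neither and carries a double bond instead. Nothing measured here explains the rise or shows which of these differences matters.

Going by these compounds, it remains open whether the nitrogen itself is what counts, which a hydroxyl in place of the amine or a longer chain ending in the amine would help to test. On these data alone, it is also open whether a plain propyl, which keeps an all-carbon chain but has no double bond, or a carboxylic acid at the end of the chain would move the number in the same direction.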